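The source may hold more compounds than are shown below. What is called first, only, known or untested is meant among the compounds shown, and "the series" means these compounds.

Measured so far in a functional assay on HCT-116 cells (Homo sapiens) for inhibition, read by sulforhodamine B assay, with a stated time of 48 h; a lower number here means a stronger inhibitor of growth, a higher number a weaker inhibitor of growth:

compound 1, `O=C(Nc1cccc(-n2cc(-c3ccncc3)c(-c3ccc(Cl)c(O)c3)n2)c1)Nc1ccc(Cl)c(Cl)c1`: 1190 nM
compound 2, `COc1cc(-c2nn(-c3cccc(NC(=O)c4cccc(C(F)(F)F)c4)c3)cc2-c2ccncc2)ccc1Cl`: 1670 nM
compound 3, `COc1cc(-c2nn(-c3cccc(NC(=O)Nc4cccc(C(F)(F)F)c4)c3)cc2-c2ccncc2)ccc1Cl`: 900 nM

Compound 2 has the highest of the three numbers, but its gaps to compound 1 and to compound 3 are both within the scatter, so no order among the three can be read. Among the compounds with values here, the one single-place step available, a 1.9-fold lower number from compound 2 to compound 3 (0.27 log units; within the scatter), swaps (3-(trifluoromethyl)phenyl)amino in for 3-(trifluoromethyl)phenyl on the carbonyl carbon and stays within the scatter.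

Compound 4, `COc1cc(-c2nn(-c3cccc(NC(=O)c4ccccc4)c3)cc2-c2ccncc2)ccc1Cl`, differs from compound 2 by hydrogen in place of trifluoromethyl on an aromatic carbon: the trifluoromethyl, sitting on an aromatic carbon of a six-membered aromatic ring of carbon only, meta to a large group, is replaced by hydrogen. Read one bond further out, this is 3-(trifluoromethyl)phenyl going to phenyl, or (3-(trifluoromethyl)phenyl)carbonyl to benzoyl. Within the data shown here, no measured step tests this change; compound 1 and compound 3 keep the trifluoromethyl or carry a different ring. With nothing in the series moving beyond the scatter, the expected step of a 1.3-fold higher number from compound 2 to compound 4 (0.12 log units; within the scatter) is likewise expected to stay within it. Compound 4 is therefore estimated at 2200 nM in this assay, within 900 nM to 5500 nM.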

Compound 4, concentration for 50% growth inhibition: 500 nM
Estimate against measurement, compound 4: 4.4-fold (0.64 log units) above; the whole stated range lies above it.
By their numbers in this assay, from the lowest: compounds 4, 3, 1 and 2 (each within the scatter of the next, the first and the last beyond it).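

In this assay, within the data shown here, hydrogen in place of trifluoromethyl on an aromatic carbon gives a 3.3-fold lower number from compound 2 to compound 4 (0.52 log units; beyond the scatter), the first step to pass beyond the scatter, and it shows that the trifluoromethyl at this place is not required for growth inhibition. Phenyl in place of (3-(trifluoromethyl)phenyl)amino on the carbonyl carbon gives a 1.8-fold lower number from compound 3 to compound 4 (0.26 log units; within the scatter), so compound 4 cannot be separated from compound 3 on this read-out. No supporting data are available to explain the modest change seen on losing the trifluoromethyl.

Still open, going by these compounds, is whether a methyl, an amine or a carboxylic acid at this place would read like hydrogen or like trifluoromethyl. Also open, on these data alone, is whether hydrogen in place of trifluoromethyl would give a similar step on the scaffold of compound 3.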